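Cytotoxicity on Vero Cells: a Methoxy to Trifluoromethoxy Step

This account rests on a few compounds, and the source may have more. Where it says the series, first, only, none or still open, it means among the compounds named here.

These three compounds share one core and are judged in an ADME assay on Vero cells (Chlorocebus sabaeus) for cytotoxicity, read by MTT assay, with a stated time of 72 h; on this read-out higher numbers stand for weaker inhibition and lower numbers for stronger inhibition. Compound 1, with the structure `COc1ccc(/C=N/NC(=O)c2cnc3c(C(F)(F)F)cccc3c2N[C@@H](CSc2ccccc2)CC(=O)N(C)C)c(F)c1`, has no result in this assay and is entered as "not determined" (no result reported). Compound 2, with the structure `CN(C)C(=O)C[C@H](CSc1ccccc1)Nc1c(C(=O)N/N=C/c2ccccc2F)cnc2ccc(F)cc12`, gives > 62.5 ug/mL in this assay; this is a limit of the assay and not a number. Within the data shown here, compound 3, with the structure `COc1ccc(/C=N/NC(=O)c2cnc3ccc(F)cc3c2N[C@@H](CSc2ccccc2)CC(=O)N(C)C)cc1`, likewise carries no result and stands as "not determined" (no result reported), so no single number places it among the others; the only value of any kind in this assay is the limit of > 62.5 ug/mL in this assay, at which 1 of the 3 values shown sits.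

Compound 4, with the structure `CN(C)C(=O)C[C@H](CSc1ccccc1)Nc1c(C(=O)N/N=C/c2ccc(OC(F)(F)F)cc2)cnc2ccc(F)cc12`, is not yet measured. It differs from compound 3 in one place: trifluoromethyl in place of methyl on an oxygen on an aromatic ring, or in other words a methoxy becoming a trifluoromethoxy. Among the measured compounds shown here, no step between two measured compounds exists to size this change, so the expectation rests only on the one limit seen for compound 2 with the value > 62.5 ug/mL. A step no larger than the usual scatter is expected, in no clear direction. For compound 4 the estimate in this assay is 62.5 ug/mL, with a range from 30 ug/mL to 125 ug/mL, and most likely again only a limit will be reported.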

Compound 4, half-maximal inhibitory concentration: > 62.5 ug/mL
Compound 4: a limit, no number; the forecaster's own chance of this, stated with the estimate: 70%; the middle value lies on the limit itself.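

Compound 2 and compound 4 each give a limit of the assay and not a number, and compound 3 offers no number, so no new step can be read from compound 2 or compound 3 to compound 4: the limit of > 62.5 ug/mL in this assay, at which 2 of the 4 values shown sit.

The compounds shown leave open where the half-maximal concentration of any of them lies, and what the change from methoxy to trifluoromethoxy does to it.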